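Series notes: from compound 1 to compound 4

The source may hold more compounds than are shown below. What is called first, only, known or untested is meant among the compounds shown, and "the series" means these compounds.

Measured so far:
compound 1 `Cc1cccc([C@H](C)NC(=O)Cn2nnc3ccccc3c2=O)c1` — 11 mL/min/kg
compound 2 `Cc1ccc([C@@H](C)NC(=O)Cn2nnc3ccccc3c2=O)cc1` — < 9.9 mL/min/kg
compound 3 `C[C@@H](NC(=O)Cn1nnc2ccccc2c1=O)c1ccccc1` — < 9.9 mL/min/kg

Among the compounds with values here, in an ADME assay on microsomes from liver (Homo sapiens) for metabolic stability (a higher number here means faster removal of the compound, a lower number slower removal), compound 1 gives 11 mL/min/kg, the only plain number among the three values shown. For compound 2 the value < 9.9 mL/min/kg is a limit of the assay, not a number. For compound 3 the value < 9.9 mL/min/kg is likewise a limit. Consequently a step that the two limits leave unreadable from compound 2 to compound 3 cannot be sized; the only step measured so far gives no usable reading, and the picture is dominated by the limit of < 9.9 mL/min/kg in this assay, at which 2 of the 3 values shown sit.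

Compound 4 `C[C@H](NC(=O)Cn1nnc2ccccc2c1=O)c1ccn(C)n1` differs from compound 1 by 1-methyl-1H-pyrazol-3-yl in place of 3-methylphenyl on a saturated chain carbon bound to an amide-type nitrogen and a saturated chain carbon. Within the data shown here, no measured step touches this change, and the one measured step is unreadable, so nothing in the set points to a shift in either direction beyond the scatter. Compound 1 already sits close to the limit, so compound 4 is expected to show a 1.2-fold lower number from compound 1 to compound 4 (0.06 log units; within the scatter), within the scatter. For compound 4 in this assay the estimate is 9.5 mL/min/kg, between 5 mL/min/kg and 18 mL/min/kg, with a substantial chance that only a limit is reported.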

Compound 4, clearance: 12 mL/min/kg
Estimate against measurement, compound 4: 1.3-fold (0.10 log units) below, within the range that was stated.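

In this assay, within the data shown here, the exchange at this position gives the first step that can be read: a 1.1-fold higher number from compound 1 to compound 4 (0.04 log units; within the scatter). The saturated chain carbon bound to an amide-type nitrogen and a saturated chain carbon therefore carries either 3-methylphenyl or 1-methyl-1H-pyrazol-3-yl without a separation in this read-out, even though the six-membered aromatic ring of carbon only gives way to a five-membered aromatic ring with 2 hetero atoms and 2 hydrogen-bond acceptors enter. Only a change of the whole aromatic group has been read here, and that change stays within the scatter.

The step from compound 2 to compound 3 cannot be read, so the methyl group on the phenyl ring remains unsized, and part of the series gives no plain number: the limit of < 9.9 mL/min/kg in this assay, at which 2 of the 4 values shown sit. On these data alone, whether an amine or a carboxylic acid at this same saturated chain carbon would give a step beyond the scatter remains open.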